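The source may report more compounds than this note shows. Statements on the series, on what has been measured and on what is new or still open speak of the compounds shown alone.

Working notes on the series.

Compound 2 `O=C1C=C(Nc2ccccc2)C(=O)c2c1nc1n2[C@H]2OC[C@@H](O)[C@H]2OC1` is the unsubstituted anilino member of the set. In a functional assay on MGC-803 cells (Homo sapiens) for inhibition, read by sulforhodamine B assay (a lower number here means a stronger inhibitor, a higher number a weaker inhibitor), compound 2 gives 1730 nM. For the measured compounds named here, the only other measured member, compound 1 `COc1ccc(NC2=CC(=O)c3c(nc4n3[C@H]3OC[C@@H](O)[C@H]3OC4)C2=O)cc1`, carries a methoxy on the same anilino ring; in this assay compound 1 gives 2150 nM. The two numbers lie within the scatter of each other, so the pair shows no resolvable effect of a methoxy on that ring at the site where compound 1 carries it. The step from compound 2 to compound 3 is not measured for any pair.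

Compound 3 `COc1ccccc1NC1=CC(=O)c2nc3n(c2C1=O)[C@H]1OC[C@@H](O)[C@H]1OC3` is the next member to be run in this assay. It differs from compound 2 by methoxy in place of hydrogen on an aromatic carbon, that is, the anilino becomes a (2-methoxyphenyl)amino. Going by the values given here, with only the pair of compound 1 and compound 2 as a guide, and their difference lying within the scatter, the step to compound 3 is expected to be small or absent beyond the scatter, with no clear direction.

Compound 3 is estimated at 2000 nM in this assay, with a range of 900 nM to 4500 nM.

The step from compound 2 to compound 3 is expected to be a 1.2-fold higher number from compound 2 to compound 3 (0.06 log units; within the scatter).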

Compound 3, half-maximal inhibitory concentration: 1630 nM
Compound 3: middle estimate off by 1.2-fold (0.09 log units), on the high side, and the stated range covers the measured number.
By their numbers in this assay, from the lowest: compounds 3, 2 and 1 (each within the scatter of the next).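

In this assay, methoxy in place of hydrogen on an aromatic carbon, ortho to a large group, gives a 1.1-fold lower number from compound 2 to compound 3 (0.03 log units; within the scatter) and so leaves the number within the scatter. Compound 1 had shown this only for the site where it carries its methoxy, whereas compound 3 extends the same result to a second placement on the anilino ring. The (2-methoxyphenyl)amino and anilino groups therefore cannot be told apart by this read-out, and this position tolerates the added methoxy without a resolvable loss or gain.

Still open, going by these compounds, is whether any replacement on this ring moves the number beyond the scatter, for instance an amine, a carboxylic acid, a fluorine atom or a longer alkoxy chain such as butoxy in the place of the methoxy. Also open, on these data alone, is whether changes to the shared core matter more than changes to the anilino ring, since all three compounds carry that core unchanged.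

No measurement is available that accounts for the size of this step.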